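A few compounds are considered here, and "the series" means these few. Any claim that something is new, unique, unknown or untested is made for them only; others in the source may bear on it.

Compound 1 `COc1ccc(C2=NN(C3=NC(=O)/C(=C4\C(=O)Nc5ccccc54)S3)C(c3ccc(OC)cc3)C2)cc1` — 91600 nM
Compound 2 `COc1ccc(C2=NN(C3=NC(=O)/C(=C4\C(=O)Nc5ccc(Br)cc54)S3)C(c3ccc(OC)cc3)C2)cc1` — 430 nM
Compound 3 `COc1ccc(C2CC(c3ccc4ccccc4c3)=NN2C2=NC(=O)/C(=C3\C(=O)Nc4ccc(Br)cc43)S2)cc1` — 220 nM

In a functional assay on cells (Cancer cell lines, Homo sapiens) for cytotoxicity, read by sulforhodamine B assay, with a stated time of 48 h (a higher number here means a weaker inhibitor of growth, a lower number a stronger inhibitor of growth), compound 2 stands second highest of the three numbers; compound 3 sits within the scatter of it, while compound 1 is a 210-fold lower number from compound 1 to compound 2 (2.33 log units; beyond the scatter) away. Compound 4 `COc1ccc(C2=NN(C3=NC(=O)/C(=C4\C(=O)Nc5ccc(Br)cc54)S3)C(c3ccc(Cl)cc3)C2)cc1` differs from compound 2 by chloro in place of methoxy on an aromatic carbon. Among the measured compounds shown here, no measured step touches this aryl group. For the measured compounds named here, the nearest precedent is the exchange of the other aryl group, a 2.0-fold lower number from compound 2 to compound 3 (0.29 log units; within the scatter), which stayed within the scatter; the large step of a 210-fold lower number from compound 1 to compound 2 (2.33 log units; beyond the scatter) concerned the bromo on a different ring and does not bear here. Compound 4 is therefore expected to show no step beyond the scatter in this assay, a 1.1-fold lower number from compound 2 to compound 4 (0.03 log units; within the scatter), with an estimate of 400 nM between 150 nM and 1200 nM.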

Compound 4, concentration for total growth inhibition: 340 nM
Compound 4: middle estimate off by 1.2-fold (0.07 log units), on the high side; low and high end bracket the measured number.
By their numbers in this assay, from the lowest: compounds 3, 4 and 2 (each within the scatter of the next); then compound 1.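

Replacing 4-methoxyphenyl with 4-chlorophenyl gives the first step shown at this aryl group, with a 1.3-fold lower number from compound 2 to compound 4 (0.10 log units; within the scatter) in this assay. The change removes the hydrogen-bond acceptor counted for methoxy, yet the step stays within the scatter, so in this pair the methoxy oxygen is not needed to keep the reading. Nothing available explains why the two groups read alike. From the compounds shown here alone, whether an amine or a carboxylic acid at this place would read the same remains open. So does whether chloro would behave alike without the bromo of compound 2.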